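A few compounds are considered here, and "the series" means these few. Any claim that something is new, unique, unknown or untested is made for them only; others in the source may bear on it.

Three compounds share one core and were tested in a functional assay on MCF7 cells (Homo sapiens) for inhibition, read by MTT assay, with a stated time of 72 h; a higher number here means a weaker inhibitor, a lower number a stronger inhibitor. Compound 1 `COc1cc2c(Oc3ccc(NC(=O)c4nn(-c5ccccc5C)cc(C)c4=O)cc3)ccnc2cc1OCCCCCC(=O)NO` gives 1830 nM in this assay. Compound 2 `COc1cc2c(Oc3ccc(NC(=O)c4nn(-c5ccccc5)cc(C)c4=O)cc3F)ccnc2cc1OCCCC(=O)NO` gives 1900 nM. Compound 3 `COc1cc2c(Oc3ccc(NC(=O)c4nn(-c5cccc(C)c5)cc(C)c4=O)cc3)ccnc2cc1OCCCCCCC(=O)NO` gives 1680 nM, a number that sits together with those of compound 1 and compound 2: the gaps between all three fall within the usual scatter of repeated measurements, so none of the three can be set apart from the others on these numbers.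

Compound 4 `COc1cc2c(Oc3ccc(NC(=O)c4nn(-c5ccc(C)cc5)cc(C)c4=O)cc3)ccnc2cc1OCCCCCCC(=O)NO` differs from compound 3 in one place: 4-methylphenyl in place of 3-methylphenyl on an aromatic nitrogen. Both groups carry the same atoms; only the arrangement of the methyl group on the ring changes. Among the measured compounds shown here, no pair of measured compounds shows what such a change does in this assay, so there is no step to lean on. With the three measured numbers all lying close together, the expectation for the step from compound 3 to compound 4 is a change of no more than the scatter, in either direction, a 1.0-fold higher number from compound 3 to compound 4 (0.01 log units; within the scatter). Compound 4 is therefore estimated at 1700 nM in this assay, with a range from 850 nM to 3400 nM.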

Compound 4, half-maximal inhibitory concentration: 2560 nM
Compound 4: middle estimate off by 1.5-fold (0.18 log units), on the low side; measured number inside the range.
By their numbers in this assay, from the lowest: compounds 3, 1, 2 and 4 (each within the scatter of the next).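

Shifting the methyl group on the phenyl ring attached to the aromatic nitrogen gives the first one-place comparison in this assay, and the step is a 1.5-fold higher number from compound 3 to compound 4 (0.18 log units; within the scatter). The step lies within the scatter, so 3-methylphenyl and 4-methylphenyl cannot be told apart at this place in this assay, even though the two compounds carry the same atoms joined differently. Nothing measured here speaks to what lies behind this result.

The phenyl and 2-methylphenyl groups appear in compound 2 and compound 1, but these compounds also differ from compound 3 elsewhere, so they cannot be compared directly at this place. Going by these compounds, what a 4-methoxyphenyl, 4-chlorophenyl or 4-aminophenyl group would do at the same place remains open.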